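Homologous phenylalkanoyl piperidines against pancreatic cells

A few compounds are considered here, and "the series" means these few. Any claim that something is new, unique, unknown or untested is made for them only; others in the source may bear on it.

Compound 1 `O=C(CCCCCCc1ccccc1)N1CCCCC1` is an amide in which a phenyl-capped chain sits on a piperidine. In a functional assay on PANC-1 cells (Homo sapiens) for cytotoxicity, read by WST assay, with a stated time of 24 h (a higher number here means a weaker inhibitor, a lower number a stronger inhibitor), compound 1 gives > 100000 nM, which is a limit of the assay rather than a number. Compound 2 `O=C(CCCCCCCc1ccccc1)N1CCCCC1` differs from compound 1 by benzyl in place of phenyl on a saturated chain carbon, six bonds along the chain from a carbonyl carbon. Compound 2 gives > 100000 nM, again a limit. The step that the two limits leave unreadable from compound 1 to compound 2 therefore cannot be read. Compound 3 `O=C(CCCCCCCCCc1ccccc1)N1CCCCC1` carries a longer chain; the difference between its core and that of compound 1 is not broken down here. Compound 3 gives > 100000 nM, also a limit. All three values sit at the limit of > 100000 nM in this assay, at which 3 of the 3 values shown sit.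

Compound 4 `O=C(CCCCCCCCCCc1ccccc1)N1CCCCC1` is unmeasured and differs from compound 3 by benzyl in place of phenyl on a saturated chain carbon, nine bonds along the chain from a carbonyl carbon. This is the same kind of change as that from compound 1 to compound 2, but made nine bonds along the chain rather than six. Since compound 3 shows only a limit and the earlier step is unreadable, the expected step that the limit leaves unreadable from compound 3 to compound 4 rests on nothing more than the shared limit. Compound 4 is estimated at 150000 nM, most likely again reported as a limit.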

Compound 4, half-maximal inhibitory concentration: > 100000 nM
Compound 4 was reported as a limit; the forecaster's own chance of this, stated with the estimate: 85%; the middle value does not contradict the limit.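

Compound 4, like compound 3, stands only at a limit in this assay, so no step between compound 3 and compound 4 can be read: the limit of > 100000 nM in this assay, at which 4 of the 4 values shown sit.

The compounds shown leave open whether chain length changes the read-out in this assay at all, and none of them yields a number.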